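Cytotoxicity notes: butoxy in place of benzylamino

The source may report more compounds than this note shows. Statements on the series, on what has been measured and on what is new or still open speak of the compounds shown alone.

The series rests on one shared core, carried by compound 1 `CC(C)CNc1nc(N)nc2c1ncn2/C=C1/CC1(CO)CO`, compound 2 `Nc1nc(NCc2ccccc2)c2ncn(/C=C3/CC3(CO)CO)c2n1` and compound 3 `CN(C)c1nc(N)nc2c1ncn2/C=C1/CC1(CO)CO`. Toxicity is read in an ADME assay on MOLT-3 cells (Homo sapiens) for cytotoxicity, with a stated time of 7 days; on this read-out higher numbers stand for lower toxicity in this test and lower numbers for higher toxicity in this test. For compound 1 the result in this assay is "not determined" (no result reported). For compound 3 the result is likewise "not determined" (no result reported). Compound 2 gives > 20000 nM, which is a limit of the assay and not a number. Among the three entries compound 2 is the only one with any read-out, and it sits at the limit of > 20000 nM in this assay, at which 1 of the 3 values shown sits. Among the measured compounds shown here, no pair of measured compounds differing in one place exists in this set, so no measured size of step is available.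

Compound 4 `CCCCOc1nc(N)nc2c1ncn2/C=C1/CC1(CO)CO` is the next compound for this assay. It differs from compound 2 by butoxy in place of benzylamino on an aromatic carbon. With compound 2 reaching only the limit, the step is expected to show no change beyond the usual scatter of this assay, and the expected step is a step that the limit leaves unreadable from compound 2 to compound 4. Compound 4 is therefore estimated at 30000 nM, with a range from 10000 nM to 100000 nM, and the result is most likely again reported only as a limit.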

Compound 4, half-maximal cytotoxic concentration: > 20000 nM
Compound 4: no number, only a limit; the forecaster's own chance of this, stated with the estimate: 75%; the middle value lies beyond the limit too.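

Compound 4, like compound 2, gives only a limit in this assay, so no step can be read for butoxy in place of benzylamino on an aromatic carbon: the limit of > 20000 nM in this assay, at which 2 of the 4 values shown sit.

The compounds shown leave open whether any group at this place on the shared core gives a cytotoxic concentration readable as a number in this assay.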